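The source may report more compounds than this note shows. Statements on the series, on what has been measured and on what is new or still open speak of the compounds shown alone.

Compound 1, `CC(C)C(NC(=O)NO)C(=O)NC1CCCCC1`, in a functional assay on MOLT-4 cells (Homo sapiens) for inhibition (a lower number here means a stronger inhibitor, a higher number a weaker inhibitor), gives > 100000 nM, which is a limit of the assay rather than a measured number.
Compound 2, `CCC(C)C1NC(=O)N(C2CCCCC2)C1=O`, in this assay gives > 200000 nM, again a limit and not a number.

Compound 1 therefore stands only at a limit: the limit of > 100000 nM in this assay, at which 1 of the 2 values shown sits. The other value shown is also a limit: the limit of > 200000 nM in this assay, at which 1 of the 2 values shown sits. Among the compounds with values here, neither compound shows a real inhibition value, and no step between two measured compounds is available, so no size of change can be read from them.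

Compound 3, `CCC(C)C(NC(=O)NO)C(=O)NC1CCCCC1`, differs from compound 1 by methyl in place of hydrogen on a saturated chain carbon, three bonds along the chain from an amide-type nitrogen and a carbonyl carbon. Because compound 1 sits at the limit of > 100000 nM in this assay, at which 1 of the 2 values shown sits, this small change is expected to move the value by nothing beyond the scatter, in either direction. The expected step, a number no higher from compound 1 to compound 3 (the limit leaves the size open), is essentially none. For compound 3 the expected value is 100000 nM, with a range from 30000 nM to 300000 nM, and most likely again only a limit would be reported.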

Compound 3, half-maximal inhibitory concentration: 150000 nM
The estimate for compound 3 lay 1.5-fold (0.18 log units) below the measured number; measured number inside the range.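

The value of compound 1 in this assay is a limit and not a number, so no size can be read for the step from it to compound 3. The compounds shown leave open whether methyl in place of hydrogen at this place changes inhibition at all.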